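Swapping benzyl for 2-methoxyphenyl on an amine nitrogen

The source may report more compounds than this note shows. Statements on the series, on what has been measured and on what is new or still open speak of the compounds shown alone.

- compound 1 `O=C1C=C(NCc2ccccc2)C(=O)c2c1nc1n2[C@H]2OC[C@@H](O)[C@H]2OC1`: > 8000 nM
- compound 2 `O=C1C(Nc2ccc(Br)cc2)=CC(=O)c2c1nc1n2[C@H]2OC[C@@H](O)[C@H]2OC1`: 5220 nM
- compound 3 `CCc1ccc(NC2=CC(=O)c3c(nc4n3[C@H]3OC[C@@H](O)[C@H]3OC4)C2=O)cc1`: 6510 nM

In a functional assay on HeLa cells (Homo sapiens) for inhibition, read by sulforhodamine B assay (a lower number here means a stronger inhibitor, a higher number a weaker inhibitor), compound 1 gives > 8000 nM, which is a limit of the assay and not a number. Compound 4 `COc1ccccc1NC1=CC(=O)c2nc3n(c2C1=O)[C@H]1OC[C@@H](O)[C@H]1OC3` has not been measured yet. It carries 2-methoxyphenyl in place of benzyl on an amine nitrogen.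

Among the compounds with values here, no measured step covers this change directly. Within the data shown here, the only measured step is a 1.2-fold higher number from compound 2 to compound 3 (0.10 log units; within the scatter), with ethyl in place of bromo on an aromatic carbon, so it says little about swapping benzyl. It does show that those two values sit close together. Like compound 4, compound 2 and compound 3 have an aromatic ring on the amine nitrogen, so a value near theirs is expected in this assay. The expected change is small, towards a lower number, and is estimated as an at least 1.3-fold lower number from compound 1 to compound 4 (0.12 log units; that floor lies within the scatter). Compound 4 is expected at about 6000 nM, with an estimated range of 2500 nM to 14000 nM.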

Compound 4, half-maximal inhibitory concentration: 2950 nM
Compound 4: middle estimate off by 2.0-fold (0.31 log units), on the high side; the measured number falls inside the stated range.
By their numbers in this assay, from the lowest: compounds 4, 2 and 3 (each within the scatter of the next, the first and the last beyond it). At a limit, above all of these: compound 1.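

In this assay, putting 2-methoxyphenyl in place of benzyl on the amine nitrogen gives an at least 2.7-fold lower number from compound 1 to compound 4 (0.43 log units; beyond the scatter), so the group on this nitrogen can move the number by more than the scatter, which the step between two aromatic groups on the same nitrogen did not show. Compound 1 gives > 8000 nM, which is a limit of the assay and not a number. The step is therefore a minimum, and its full size cannot be read from these values: the limit of > 8000 nM in this assay, at which 1 of the 4 values shown sits.

The compounds shown leave open whether the methoxy group matters or whether an aromatic ring bonded straight to the nitrogen is enough, and an unsubstituted phenyl group would separate the two. As far as these compounds go, how a chain ending in a carboxylic acid or a morpholine would fare on this nitrogen also remains open.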